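Swapping the cyanophenyl arm for a pyridine in an indoline sulfonamide

A few compounds are considered here, and "the series" means these few. Any claim that something is new, unique, unknown or untested is made for them only; others in the source may bear on it.

This account follows a single change to compound 1, whose structure is `COc1ccc(S(=O)(=O)N2CCc3cccc(-c4ccc(C#N)cc4)c32)cc1`. In a functional assay on KB-VIN10 cells (Homo sapiens) for inhibition, with a stated time of 72 h (on this read-out higher numbers stand for weaker inhibition and lower numbers for stronger inhibition), compound 1 gives 29.2 nM, the lowest of the three numbers recorded. Its nearest neighbour is compound 2, `COc1ccc(S(=O)(=O)N2CCc3cccc(-c4ccc(F)nc4)c32)cc1`, which in this assay gives 151 nM; the two differ only in the aromatic arm, and the step is a 5.2-fold higher number from compound 1 to compound 2 (0.71 log units; beyond the scatter). Within the data shown here, the third measured compound, compound 3, `COc1ccc(S(=O)(=O)n2ccc3cccc(-c4ccc(F)cc4)c32)cc1`, carries a different core and a fluorophenyl arm, and in this assay compound 3 gives 202 nM; as no single-point step connects it to compound 1, the two values simply show that compound 3 sits well above compound 1.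

The unmeasured compound is compound 4, `COc1ccc(S(=O)(=O)N2CCc3cccc(-c4ccncc4)c32)cc1`. Relative to compound 1 the change is pyridin-4-yl in place of 4-cyanophenyl on an aromatic carbon. Among the measured compounds shown here, the only measured step that bears on it is the one from compound 1 to compound 2, where the 4-cyanophenyl was also exchanged for a pyridine ring and the number rose modestly but beyond the scatter. On that basis the step in this assay from compound 1 to compound 4 is expected to be a rise of similar size, a 4.1-fold higher number from compound 1 to compound 4 (0.61 log units; beyond the scatter). Compound 4 is therefore estimated at 120 nM, within a range of 40 nM to 400 nM.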

Compound 4, half-maximal inhibitory concentration: 106 nM
Beside the measured number, compound 4's estimate is 1.1-fold (0.05 log units) above it; the range from low to high includes it.
By their numbers in this assay, from the lowest: compound 1; then compounds 4, 2 and 3 (each within the scatter of the next).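

In this assay, the step from the 4-cyanophenyl arm to a pyridin-4-yl arm is a 3.6-fold higher number from compound 1 to compound 4 (0.56 log units; beyond the scatter), so a second pyridine on this aromatic carbon also stands apart from compound 1, and the earlier rise is not confined to the fluorinated ring of compound 2. The two pyridine arms cannot be separated at this position, as the exchange of 6-fluoropyridin-3-yl for pyridin-4-yl is a 1.4-fold lower number from compound 2 to compound 4 (0.15 log units; within the scatter), which leaves the fluorine and the point of attachment of the ring with no visible bearing on this read-out. No supporting data are available to explain why the 4-cyanophenyl arm gives the lowest number of the set.

Still open, on these data alone, is whether that lower number belongs to the nitrile or to the ring of carbon only, a question that a plain phenyl arm on the same core would address. Also open, as far as these compounds go, is how this position would respond to a pyridine ring that carries a nitrile, or to a phenyl ring that carries a carboxylic acid or an amine.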